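The compounds below may be only part of what the source reports. "The series", "measured", "known", "first", "only" and "open" are said of these compounds alone.

Compound 1 `CC(C)c1nc2ccc(Cl)cc2c(-c2ccc(F)cc2)c1/C=C/[C@@H]1C[C@@H](O)CC(=O)O1`: 25 nM in an assay for inhibition of 3-hydroxy-3-methylglutaryl-coenzyme A reductase (Rattus norvegicus); a lower number here means a stronger inhibitor, a higher number a weaker inhibitor.
Compound 2 `CC(C)c1nc2ccc(F)cc2c(-c2ccc(F)cc2)c1/C=C/[C@@H]1C[C@@H](O)CC(=O)O1`: 200 nM in this assay.

Compound 1 gives the lowest of the two numbers in this assay; the nearest is compound 2, at an 8.0-fold higher number from compound 1 to compound 2 (0.90 log units; beyond the scatter). Compound 3 `COc1ccc2nc(C(C)C)c(/C=C/[C@@H]3C[C@@H](O)CC(=O)O3)c(-c3ccc(F)cc3)c2c1` carries methoxy in place of chloro on an aromatic carbon. Within the data shown here, no measured step exchanges chloro for methoxy at this place. Among the measured compounds shown here, the one step that bears on it, an 8.0-fold higher number from compound 1 to compound 2 (0.90 log units; beyond the scatter), shows that removing chloro for a smaller halogen costs potency in this assay. Compound 3 is therefore expected to fall somewhat behind compound 1, by a 3.2-fold higher number from compound 1 to compound 3 (0.51 log units; beyond the scatter). The estimate for compound 3 is 80 nM, within 25 nM to 300 nM.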

Compound 3, half-maximal inhibitory concentration: 53 nM
Compound 3: the middle estimate sits 1.5-fold (0.18 log units) above what was measured, and the stated range covers the measured number.
By their numbers in this assay, from the lowest: compound 1; then compound 3; then compound 2.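

A halogen is not required at this position: in this assay, methoxy in place of chloro brings only a modest loss, with a 2.1-fold higher number from compound 1 to compound 3 (0.33 log units; beyond the scatter). Methoxy in place of fluoro instead brings a gain, with a 3.8-fold lower number from compound 2 to compound 3 (0.58 log units; beyond the scatter). Among these three compounds, methoxy therefore falls between the two halogens, so the order does not separate halogen from non-halogen groups.

No available evidence accounts for this order. From the compounds shown here alone, how an amine, a longer chain such as ethoxy, or plain hydrogen would rank at this position remains open.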